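The source may report more compounds than this note shows. Statements on the series, on what has been measured and on what is new or still open speak of the compounds shown alone.

Compound 1 `CN/C(C)=N/C1=Nc2ccccc2CS1`, compound 3 `CCN(CC)/C(C)=N/C1=Nc2ccccc2CS1` and compound 2 `CCCN(CCC)/C(C)=N/C1=Nc2ccccc2SC1` share one core and differ only in the group attached to a carbon with a double bond to nitrogen. In a functional assay (strain Wistar) with Rattus norvegicus as the target (a lower number here means that less compound is needed, a higher number that more compound is needed for the effect), compound 1 gives 0.01 uM. In this assay compound 3 gives 0.1 uM, the highest of the two numbers recorded, so more of compound 3 is needed than of compound 1. Compound 2 in this assay is reported as "not active" (no number reported), without a number. Among the measured compounds shown here, the one measured step, a 10-fold higher number from compound 1 to compound 3 (1.00 log units; beyond the scatter), shows that exchanging methylamino for diethylamino raised the number. Compound 4 `C/C(=N\C1=Nc2ccccc2CS1)N(C)C` has not yet been measured; it carries dimethylamino in place of diethylamino on a carbon with a double bond to nitrogen. Dimethylamino lies between methylamino and diethylamino in size, so compound 4 sits between compound 1 and compound 3 in this respect. Because of a 10-fold higher number from compound 1 to compound 3 (1.00 log units; beyond the scatter) a lower number than for compound 3 is expected, though not necessarily as low as for compound 1. Compound 4 is expected to show the step of a 3.3-fold lower number from compound 3 to compound 4 (0.52 log units; beyond the scatter). Compound 4 is therefore estimated at 0.03 uM, with a likely range from 0.01 uM to 0.1 uM.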

Compound 4, minimum effective concentration: 5 uM
Beside the measured number, compound 4's estimate is 170-fold (2.22 log units) below it; measured number outside the range, above it.
By their numbers in this assay, from the lowest: compound 1; then compound 3; then compound 4.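

At this position, the number in this assay does not follow the size of the group on the carbon with a double bond to nitrogen. Dimethylamino has fewer heavy atoms than diethylamino, yet exchanging diethylamino for dimethylamino gives a 50-fold higher number from compound 3 to compound 4 (1.70 log units; beyond the scatter), so compound 4 goes against any steady trend with size. The change of methyl in place of hydrogen on the amine nitrogen gives a 500-fold higher number from compound 1 to compound 4 (2.70 log units; beyond the scatter), showing that a small edit at this nitrogen can produce a large shift, much larger than the earlier step to the diethylamino group.

No measurement shown here explains this uneven pattern. As far as these compounds go, it remains open how ethylamino, ethylmethylamino or a ring amine such as pyrrolidine would behave at this place, and whether any of them would fit the low number of compound 1 or the high number of compound 4.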